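The source may hold more compounds than are shown below. What is called first, only, known or untested is meant among the compounds shown, and "the series" means these compounds.

Measured so far:
compound 1, `CCCCCCC#Cc1ccc(S(=O)(=O)Nc2cccc(-c3csc(NC(C)=O)n3)c2)cc1`, in a functional assay on A-375 cells (Homo sapiens) for antiproliferative activity, read by trypan blue exclusion, with a stated time of 48 h, tested at 5 uM; a higher number here means a weaker effect of the compound at the concentration tested, a lower number a stronger effect: 12.8%
compound 2, `CC(=O)Nc1nc(-c2cccc(NS(=O)(=O)c3ccc(C#CCO)cc3)c2)cs1`, in this assay: 99.3%

Among the compounds with values here, compound 2 stands highest of the two numbers; the single measured step, a number 86.5 percentage points higher from compound 1 to compound 2 (beyond the scatter), is large and beyond the scatter. Compound 3, `CC(=O)Nc1nc(-c2cccc(NS(=O)(=O)c3ccc(C#CC4CCCCC4)cc3)c2)cs1`, differs from compound 2 by cyclohexyl in place of hydroxymethyl on a triple-bonded carbon. The step that bears on this is a number 86.5 percentage points higher from compound 1 to compound 2 (beyond the scatter), which removed a carbon chain and introduced the hydroxy; the change to compound 3 goes the other way, removing the hydroxy-bearing chain end and adding a carbon-only ring, so a large downward step in this assay is expected, a number 74.3 percentage points lower from compound 2 to compound 3 (beyond the scatter). For compound 3 the expected value is 25%, within 8% to 60%.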

Compound 3, a percentage reported as activity, at one concentration (the size of the read-out at that concentration, not a potency): 1.2%
The estimate for compound 3 lay 23.8 percentage points above the measured number; the whole stated range lies above it.
By their numbers in this assay, from the lowest: compound 3; then compound 1; then compound 2.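

In this assay, the change on the triple-bonded carbon gives a number 98.1 percentage points lower from compound 2 to compound 3 (beyond the scatter), so a strong effect at this position does not depend on an open carbon chain. Cyclohexyl in place of hexyl gives a number 11.6 percentage points lower from compound 1 to compound 3 (beyond the scatter), a modest step, showing that the ring at least matches the chain here and goes somewhat beyond it. No evidence on hand accounts for either step.

Still open, as far as these compounds go, is whether a smaller cyclopropyl ring or an aromatic phenyl ring would hold this effect. Also open, from the compounds shown here alone, is whether an amine on the cyclohexyl ring would keep it.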